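A few compounds are considered here, and "the series" means these few. Any claim that something is new, unique, unknown or untested is made for them only; others in the source may bear on it.

Measured in an ADME assay on BJ cells (Homo sapiens) for cytotoxicity, with a stated time of 72 h; a higher number here means that more compound is needed for the effect, a lower number that less compound is needed:
- Compound 1 (`CSc1ccc(NC(=O)Nc2cc(C)nc3ccccc23)cc1`) gives > 25000 nM
- Compound 2 (`CCc1ccc(NC(=O)Nc2cc(C)nc3ccccc23)cc1`) gives > 25000 nM
- Compound 3 (`Cc1cc(NC(=O)Nc2ccc(O)cc2)c2ccccc2n1`) gives > 25000 nM

Each of these three entries is a limit and not a number. Compound 3 therefore has only its limit of > 25000 nM to stand on in this assay. All of the measured compounds share one limit (the limit of > 25000 nM in this assay, at which 3 of the 3 values shown sit). Compound 4 (`Cc1cc(NC(=O)Nc2ccc(OC(F)(F)F)cc2)c2ccccc2n1`) differs from compound 3 as hydroxy to trifluoromethoxy (trifluoromethyl in place of hydrogen on an oxygen on an aromatic ring).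

Going by the values given here, three measured steps bear on this change, all of them exchanges of groups on an aromatic carbon: a step that the two limits leave unreadable from compound 1 to compound 2, a step that the two limits leave unreadable from compound 1 to compound 3 and a step that the two limits leave unreadable from compound 2 to compound 3. None of them has a readable size, so they offer no measured effect of any such exchange. With only shared limits to go on, no step beyond the scatter is expected in this assay, though a modest move to a lower number cannot be excluded. The expected step is a number no higher from compound 3 to compound 4 (the limit leaves the size open).

For compound 4 the estimated value is 25000 nM, with an expected range from 10000 nM to 40000 nM.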

Compound 4, half-maximal effective concentration: 25000 nM
Compound 4: middle estimate and measured number agree at the digits printed; low and high end bracket the measured number.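

In this assay compound 4 gives 25000 nM, the only entry in this set that is a number and not a limit. Compound 3 has only a limit, > 25000 nM. The entries show a number no higher from compound 3 to compound 4 (the limit leaves the size open), a number no higher from compound 2 to compound 4 (the limit leaves the size open) and a number no higher from compound 1 to compound 4 (the limit leaves the size open). The size of these steps cannot be read, since the other compounds all stay at one limit: the limit of > 25000 nM in this assay, at which 3 of the 4 values shown sit.

The compounds shown therefore leave open how much, if at all, trifluoromethyl on this oxygen moves the number away from that of the hydroxy compound. They also leave open whether an amine, a carboxylic acid or a longer chain in place of trifluoromethoxy on this aromatic carbon would give a clearly lower number.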